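A ring in place of a chain: compound 4

A few compounds are considered here, and "the series" means these few. Any claim that something is new, unique, unknown or untested is made for them only; others in the source may bear on it.

Among the compounds with values here, in a physicochemical assay for lipophilicity, using the shake flask method, in phosphate buffer, measured as octanol-water partition, with a stated time of 30 min, at pH 7.4 (on this read-out lower numbers stand for lower lipophilicity and higher numbers for higher lipophilicity), compound 3 `COCCC(=O)Nc1cnc(NCc2c(F)ccc3c2CCO3)n2cnnc12` gives 1.4, the lowest of the three numbers so far. Compound 1 `O=C1c2ccccc2CN1c1cnc(NCc2c(F)ccc3c2CCO3)n2cnnc12` gives 2.7, and compound 2 `Fc1ccc2c(c1CNc1ncc(Oc3ccccc3)c3nncn13)CCO2` gives 3.5. Compound 4 `CC1(C)CC(=O)N(c2cnc(NCc3c(F)ccc4c3CCO4)n3cnnc23)C1` has 4,4-dimethyl-2-oxopyrrolidin-1-yl in place of ((2-methoxyethyl)carbonyl)amino on an aromatic carbon. Within the data shown here, two measured steps bear on this change, both large: a number 2.10 log units lower from compound 2 to compound 3 (beyond the scatter) and a number 1.30 log units lower from compound 1 to compound 3 (beyond the scatter). The second is the closer guide, since the group on compound 1 also has a five-membered non-aromatic ring, plus an aromatic ring that the new group lacks. Only part of that step is therefore expected to return, upward and beyond the scatter, and in this assay the expected step is a number 0.80 log units higher from compound 3 to compound 4 (beyond the scatter). For compound 4 the estimate is 2.2, with an expected range of 1.7 to 2.7.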

Compound 4, distribution coefficient: 2
The estimate for compound 4 lay 0.20 log units above the measured number, and the stated range covers the measured number.
By their numbers in this assay, from the lowest: compound 3; then compound 4; then compound 1; then compound 2.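

In this assay, 4,4-dimethyl-2-oxopyrrolidin-1-yl in place of the open chain gives a number 0.60 log units higher from compound 3 to compound 4 (beyond the scatter). The new group, which has a ring but no aromatic ring, still reads lower than the two groups that carry an aromatic ring: a number 1.50 log units lower from compound 2 to compound 4 (beyond the scatter) and a number 0.70 log units lower from compound 1 to compound 4 (beyond the scatter). No measurement shown here explains these steps. The compounds shown leave open how much of the rise belongs to the ring, to its two methyl groups, or to the loss of the amide hydrogen, as all three change together. From the compounds shown here alone, how a plain pyrrolidinone without methyl groups or an amine at this position would read also remains open.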